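Ester-to-amide step in a branched dienoate series

The compounds below may be only part of what the source reports. "The series", "measured", "known", "first", "only" and "open" are said of these compounds alone.

Measured so far:
compound 1, `CC(/C=C/CC(C)CCCC(C)C)=C\C(=O)OCC(C)C`, 7.69
compound 2, `CC(/C=C/CC(C)CCCC(C)(C)C)=C\C(=O)OC(C)C`, 7.56

In a physicochemical assay for lipophilicity (a higher number here means a more lipophilic compound, a lower number a more polar compound), compound 1 gives 7.69. Compound 2 gives 7.56 in this assay, and the two numbers lie within the scatter of each other, so no order between compound 1 and compound 2 can be read from them. Going by the values given here, no step between two measured compounds that differ in a single place has been worked out.

Compound 3, `CC(/C=C/CC(C)CCCC(C)C)=C\C(=O)NCC(C)C`, has not yet been measured in this assay. It differs from compound 1 as follows: isobutylamino in place of isobutoxy on a carbonyl carbon. Cut one bond further out, the same difference reads isobutoxycarbonyl to isobutylcarbamoyl.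

For compound 3 a step downward, well beyond the scatter, is expected in this assay, of the size a number 1.29 log units lower from compound 1 to compound 3 (beyond the scatter). Compound 3 is estimated at 6.4 in this assay, within a range from 5.8 to 7. Among the compounds with values here, the expectation rests on compound 1 alone, at 7.69, since no measured pair carries this change.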

Compound 3, partition coefficient: 6.19
Estimate against measurement, compound 3: 0.21 log units above; low and high end bracket the measured number.
By their numbers in this assay, from the lowest: compound 3; then compounds 2 and 1 (each within the scatter of the next).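

In this assay, going by these compounds alone, the change to isobutylamino in place of isobutoxy on a carbonyl carbon gives a number 1.50 log units lower from compound 1 to compound 3 (beyond the scatter) and is the first step that isolates a single place, with a large size. Both groups carry the same isobutyl carbons, and the rest of the core of compound 1 stays as it is, so the number at this position responds to the exchange of the oxygen for a nitrogen bearing a hydrogen-bond donor, with no change in chain length or branching. Nothing measured here bears on why the step has this size.

Open, going by these compounds, is whether the amide hydrogen itself is tied to the step, which a tertiary amide with a methyl group on the nitrogen would separate from the simple exchange of oxygen for nitrogen. Also open, on these data alone, is whether the step keeps its size on the chain of compound 2, or when a carboxylic acid, a primary amide or a longer chain on the nitrogen sits on the same carbonyl carbon.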